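The source may hold more compounds than are shown below. What is called first, only, known or untested is meant among the compounds shown, and "the series" means these compounds.

Compound 1, `Cc1cn(COC(CO)CO)c(=O)[nH]c1=O`, reaches in a functional assay on Vero cells (Chlorocebus sabaeus) for cytotoxicity (a lower number here means that less compound is tolerated, a higher number that more compound is tolerated), only the assay's limit, > 434000 nM.
Compound 2, `Cc1cc(=O)[nH]c(=O)n1COC(CO)CO`, reaches in this assay only the assay's limit, > 434000 nM.
Compound 3, `Cc1c(Br)c(=O)[nH]c(=O)n1COC(CO)CO`, reaches in this assay only the assay's limit, > 324000 nM.

Compound 3 therefore stands nowhere in particular on these numbers: its value is a limit, and the two further values are limits as well, so none of the three can be set in order against another. Among the compounds with values here, the one step among the measured compounds, a step that the two limits leave unreadable from compound 2 to compound 3, cannot be read because both its ends are limits (the limit of > 324000 nM in this assay, at which 1 of the 3 values shown sits, (the limit of > 434000 nM in this assay, at which 2 of the 3 values shown sit)).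

Compound 4, `Cc1c(I)c(=O)[nH]c(=O)n1COC(CO)CO`, differs from compound 3 by iodo in place of bromo on an aromatic carbon. Within the data shown here, no measured step bears on this change in a readable way; the exchange of one halogen for another, on the same aromatic carbon, is the only change, and every compound of this series so far has stayed tolerated up to the limit of this assay. Compound 4 is therefore expected to behave the same way, with no step beyond the scatter, so that an at least 1.0-fold lower number from compound 3 to compound 4 (0.00 log units; that floor lies within the scatter) is the estimate, and the assay will most likely again report only a limit. The estimate for compound 4 in this assay is 320000 nM, within 100000 nM to 1000000 nM.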

Compound 4, half-maximal cytotoxic concentration: > 280000 nM
Compound 4: no number, only a limit; the forecaster's own chance of this, stated with the estimate: 85%; the middle value is on the limit's open side.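

In this assay compound 4 gives only a limit, > 280000 nM. Neither step to compound 4, from compound 2 or from compound 3, can be read, as all three values are limits. The compounds shown leave open where the half-maximal cytotoxic concentration of each lies, and whether hydrogen, bromo or iodo on that aromatic carbon makes any difference in this assay.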